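The source may hold more compounds than are shown below. What is called first, only, known or untested is meant among the compounds shown, and "the series" means these compounds.

Compound 1 `N#Cc1ccc(NC(=O)Nc2ccc(F)c(C(F)(F)F)c2)cc1` was tested in a physicochemical assay for solubility, read by nephelometry, measured as kinetic solubility, at pH 2; a lower number here means a less soluble compound, a higher number a more soluble compound. In this assay compound 1 gives only a limit of the assay, < 1.6 ug/mL, and not a number. Its reading is the limit of < 1.6 ug/mL in this assay, at which 1 of the 2 values shown sits. Compound 2 `Cc1cc(NC(=O)Nc2ccc(F)c(C(F)(F)F)c2)on1`, which shares the same core, gives 12.5 ug/mL in this assay. Compound 3 `NC(=O)c1ccc(NC(=O)Nc2ccc(F)c(C(F)(F)F)c2)cc1` has not yet been measured; it differs from compound 1 by carbamoyl in place of cyano on an aromatic carbon. For the measured compounds named here, no step between measured compounds is given here, so only an expectation can be stated: a moderate rise in solubility, an at least 3.1-fold higher number from compound 1 to compound 3 (0.49 log units; beyond the scatter), is expected. Compound 3 is estimated at 5 ug/mL, with a range from 1.6 ug/mL to 20 ug/mL.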

Compound 3, solubility: 6.3 ug/mL
Compound 3: the middle estimate sits 1.3-fold (0.10 log units) below what was measured, within the range that was stated.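

Putting carbamoyl in place of cyano on this aromatic carbon, para to a large group, gives an at least 3.9-fold higher number from compound 1 to compound 3 (0.59 log units; beyond the scatter) in this assay. With this change the series with a six-membered aromatic ring of carbon only now has a numerical reading. The true size of the step stays unknown because compound 1 gives a limit of the assay and not a number: the limit of < 1.6 ug/mL in this assay, at which 1 of the 3 values shown sits.

The compounds shown leave open how an amine, a carboxylic acid or a methyl ester at this position would read in this assay. They also leave open whether the same exchange would give a comparable step on another core.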